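Exchanging one pyridine position for another on the side chain

The source may hold more compounds than are shown below. What is called first, only, known or untested is meant among the compounds shown, and "the series" means these compounds.

Compound 2 `Cc1nc(NCc2ccccn2)nc(N[C@@H]2C[C@H](CO)[C@@H](O)[C@H]2O)c1-c1nc2ccccc2s1` is one of two compounds of a shared core measured in an ADME assay on cells (Homo sapiens) for cytotoxicity, read by polymerase chain reaction, with a stated time of 3 days; on this read-out higher numbers stand for lower toxicity in this test and lower numbers for higher toxicity in this test. In this assay compound 2 gives 13000 nM, the only number shown among the two values. Compound 1 `Cc1nc(NCC2CCC2)nc(N[C@@H]2C[C@H](CO)[C@@H](O)[C@H]2O)c1-c1nc2ccccc2s1` gives > 25000 nM in this assay, which is a limit rather than a number, in keeping with the limit of > 25000 nM in this assay, at which 1 of the 2 values shown sits. Within the data shown here, the single measured step, an at least 1.9-fold lower number from compound 1 to compound 2 (0.28 log units; that floor lies within the scatter), is the only comparison available, and its floor lies within the scatter. Compound 3 `Cc1nc(NCc2ccncc2)nc(N[C@@H]2C[C@H](CO)[C@@H](O)[C@H]2O)c1-c1nc2ccccc2s1` differs from compound 2 in that (pyridin-4-yl in place of pyridin-2-yl on a saturated chain carbon bound to a nitrogen on an aromatic ring); the two have the same atoms, joined differently. Among the measured compounds shown here, no measured step exchanges one pyridine position for another, so the step from cyclobutyl to pyridin-2-yl bears on it only loosely, and it did not itself rise beyond the scatter. On this basis no step beyond the scatter is expected in this assay from compound 2 to compound 3, that is a 1.2-fold higher number from compound 2 to compound 3 (0.06 log units; within the scatter). Compound 3 is therefore estimated at 15000 nM in this assay, with an expected range from 6000 nM to 40000 nM.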

Compound 3, half-maximal cytotoxic concentration: 7000 nM
Compound 3: the middle estimate sits 2.1-fold (0.33 log units) above what was measured; measured number inside the range.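

The exchange of pyridine positions now has a direct reading in this assay: on a saturated chain carbon bound to a nitrogen on an aromatic ring, the change gives a 1.9-fold lower number from compound 2 to compound 3 (0.27 log units; within the scatter), so pyridin-2-yl and pyridin-4-yl cannot be told apart in this test. What the earlier pair did not show is a step on this side chain that clears the scatter, and the replacement of cyclobutyl by pyridin-4-yl provides one, with an at least 3.5-fold lower number from compound 1 to compound 3 (0.55 log units; beyond the scatter), whereas the floor of the step from cyclobutyl to pyridin-2-yl stayed within the scatter. The size of this new step is only a floor, since its starting point is a limit and not a number: the limit of > 25000 nM in this assay, at which 1 of the 3 values shown sits.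

The compounds shown leave open whether a phenyl ring in the same place, with no ring nitrogen, would read with the cyclobutyl of compound 1 or with the pyridine of compound 3. They also leave open how a side chain ending in a dimethylamino group or a carboxylic acid would read in this assay on the shared core.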